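The compounds below may be only part of what the source reports. "The series", "measured", "known", "first", "only" and "open" are said of these compounds alone.

Measured compounds:
compound 1, `COc1ccccc1C(=O)OC1CCN(C)CC1`, 1.43
compound 2, `Cc1ccc(C(=O)OC2CCN(C)CC2)cc1`, 1.17

The two compounds share one core and differ only in the group carried on the aromatic ring. In a functional assay on the whole organism with Mus musculus as the target (on this read-out lower numbers stand for lower potency and higher numbers for higher potency (the scale is a negative logarithm)), compound 1 gives 1.43. In this assay compound 2 gives 1.17. Of the two numbers shown, that of compound 2 is the lower, yet the gap to compound 1 lies within the scatter, so the two cannot be told apart on these data. Within the data shown here, no step between measured compounds that differ in a single place is available, so nothing is yet known about how a swap of the group on the aromatic ring moves this assay.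

Compound 3, `CN1CCC(OC(=O)c2ccc(Cl)cc2)CC1`, is the compound still to be measured. Relative to compound 2 the change is chloro in place of methyl on an aromatic carbon. Among the measured compounds shown here, with no measured step to lean on, and the two known values lying close together, the expectation is that the step of a number 0.13 log units higher from compound 2 to compound 3 (within the scatter) stays within the scatter, in either direction, without a clear shift. The estimate for compound 3 in this assay is therefore 1.3, with a range from 0.8 to 1.8.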

Compound 3, logarithm of the reciprocal of the active concentration, log(1/C): 1.11
The estimate for compound 3 lay 0.19 log units above the measured number; the measured number falls inside the stated range.
By their numbers in this assay, from the lowest: compounds 3, 2 and 1 (each within the scatter of the next, the first and the last beyond it).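

Among these compounds, for the first time, a change in a single place can be read on the aromatic carbon para to a large group: in this assay the exchange of methyl for chloro amounts to a number 0.06 log units lower from compound 2 to compound 3 (within the scatter) and does not separate the two compounds on these data. At this place, then, one heavy atom replaced by another, with the counted hydrogen-bond donors, hydrogen-bond acceptors and net charge all unchanged, gives no shift that can be told from the scatter of repeated measurements. Nothing measured alongside these numbers speaks to why the step has this size.

Going by these compounds, whether a group of another kind on this carbon, such as an amine, a carboxylic acid or a longer alkyl chain, would move the read-out beyond the scatter stays open, as does the effect of plain hydrogen there. On these data alone, compound 1 differs from compound 2 and from compound 3 in more than one place, so the steps to it cannot be read, and what its methoxy group contributes in this assay remains unknown.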